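A few compounds are considered here, and "the series" means these few. Any claim that something is new, unique, unknown or untested is made for them only; others in the source may bear on it.

Measured compounds in a physicochemical assay for solubility, read by HPLC, in phosphate buffer, measured as kinetic solubility, with a stated time of 24 h, at 20 degrees C, at pH 7.4, tested at 100 uM; on this read-out lower numbers stand for lower solubility and higher numbers for higher solubility:
- compound 1 `CNc1nc2c(c(-c3ccc4oc(N)nc4c3)nn2C(C)C)c(=O)[nH]1`: < 1000 nM
- compound 2 `Cc1nc2c(c(-c3ccc4oc(N)nc4c3)nn2C(C)C)c(=O)[nH]1`: 3000 nM

Compound 1 sits at a limit of this assay, and its value is a limit rather than a number (the limit of < 1000 nM in this assay, at which 1 of the 2 values shown sits). Within the data shown here, compound 2 gives the only number in this assay; the one further result is a limit. Among the measured compounds shown here, the one measured step, an at least 3.0-fold higher number from compound 1 to compound 2 (0.47 log units; beyond the scatter), is the exchange of methylamino for methyl on an aromatic carbon, and because compound 1 sits at a limit of < 1000 nM in this assay, at which 1 of the 2 values shown sits, only a lower bound of its size is known.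

Compound 3 `CC(C)n1nc(-c2ccc3oc(N)nc3c2)c2c(=O)[nH]cnc21` is the next member. It differs from compound 2 by hydrogen in place of methyl on an aromatic carbon. For the measured compounds named here, no measured step covers the removal of a methyl group from this position; the only step known concerns a different exchange at the same carbon, and its size is bounded, not fixed. The change is small in heavy-atom terms, so no movement in this assay beyond the scatter is expected, with the estimated step of no change at the digits printed from compound 2 to compound 3 (within the scatter) from compound 2 to compound 3. For compound 3 the estimate in this assay is 3000 nM, expected to lie between 1000 nM and 9000 nM.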

Compound 3, solubility: 3000 nM
Compound 3: middle estimate and measured number agree at the digits printed, within the range that was stated.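

In this assay, hydrogen in place of methyl on an aromatic carbon between two ring nitrogen atoms gives no change at the digits printed from compound 2 to compound 3 (within the scatter), so this position now has two small substituents that read alike and the methyl group is not required to hold the reading at this level. Hydrogen in place of methylamino at the same carbon gives an at least 3.0-fold higher number from compound 1 to compound 3 (0.47 log units; beyond the scatter), which means that methylamino stands apart from both methyl and hydrogen across the three compounds shown, and the earlier single step could not show this. The size of that separation remains a bound, as compound 1 carries a limit and not a number: the limit of < 1000 nM in this assay, at which 1 of the 3 values shown sits.

From the compounds shown here alone, whether a larger carbon substituent at this carbon, such as an ethyl or isopropyl chain, would read with methyl and hydrogen or with methylamino stays open. An unsubstituted amine, a dimethylamino group or a methoxy group at the same carbon would show whether the separation belongs to methylamino alone or to groups attached through a heteroatom more widely.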